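The source may report more compounds than this note shows. Statements on the series, on what has been measured and on what is new or still open speak of the compounds shown alone.

Compound 1 `Cc1cc(Nc2cc(-c3ccccc3)[nH]n2)n2nc(SCc3c(Cl)cccc3Cl)nc2n1` is one of three compounds tested in a functional assay on PC-9 cells (Homo sapiens) for inhibition, read by MTT assay, with a stated time of 72 h; a lower number here means a stronger inhibitor, a higher number a weaker inhibitor. In this assay compound 1 gives 5180 nM, the lowest of the two numbers that were read; compound 2 `Cc1cc(Nc2ccn(Cc3cccc4ccccc34)n2)n2nc(SCc3ccc(Br)cc3)nc2n1` gives 5660 nM, which lies within the scatter of compound 1, so the two cannot be told apart. For compound 3 `CCCCCc1c(C)nc2nc(SCc3ccc(Cl)cc3)nn2c1Nc1cc(-c2ccccc2)[nH]n1` this assay reports only a limit, > 50000 nM, not a number (the limit of > 50000 nM in this assay, at which 1 of the 3 values shown sits).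

Compound 4 `C#CCSc1nc2nc(C)cc(Nc3cc(-c4ccccc4)[nH]n3)n2n1` is not yet measured. Its structure differs from compound 1 in one place: ethynyl in place of 2,6-dichlorophenyl on a saturated chain carbon bound to a sulfur.

Within the data shown here, no measured pair shows a change of this kind, so no step can be read off. The expectation for compound 4 is a weaker inhibitor, with the step from compound 1 estimated as a 2.9-fold higher number from compound 1 to compound 4 (0.46 log units; beyond the scatter), beyond the scatter. Compound 4 is expected to give about 15000 nM, between 5000 nM and 50000 nM.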

Compound 4, half-maximal inhibitory concentration: > 50000 nM
Compound 4 ended at the assay's limit (the forecaster's own chance of this, stated with the estimate: 25%); middle value at least 3.3-fold (0.52 log units) away from the limit.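

In this assay, replacing 2,6-dichlorophenyl with ethynyl on a saturated chain carbon bound to a sulfur gives an at least 9.6-fold higher number from compound 1 to compound 4 (0.98 log units; beyond the scatter). Among these compounds, this is the first change in one place that can be read, and it shows that the group at this position matters, which the earlier compounds, differing in several places, could not show. The reading of compound 4 is a limit and not a number: the limit of > 50000 nM in this assay, at which 2 of the 4 values shown sit.

Going by these compounds, whether the ring alone is enough or the two chlorines are also needed stays open. An unsubstituted benzyl group at this position would separate the two.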